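The compounds below may be only part of what the source reports. "The series", "measured", "known", "first", "only" and "open" are said of these compounds alone.

Measured so far in a functional assay on U-87MG ATCC cells for inhibition, with U-87 MG (Homo sapiens) as the target, read by MTT assay, with a stated time of 48 h; a lower number here means a stronger inhibitor, a higher number a weaker inhibitor:
- compound 1 `Fc1ccc(/C=N/Nc2nc(-c3ccc(C(F)(F)F)cc3)cs2)cc1F`: 29900 nM
- compound 2 `Fc1ccc(/C=N/Nc2nc(-c3ccc(Br)cc3)cs2)cc1F`: > 100000 nM
- compound 3 `COc1cc(/C=N/Nc2nc(-c3ccc(C(F)(F)F)cc3)cs2)cc(Br)c1OC`: 41000 nM

Compound 1 gives 29900 nM in this assay and compound 3 gives 41000 nM; the two values lie within the usual scatter of each other. For compound 2 only a limit is recorded, > 100000 nM, so no number is known for it; it stands at the limit of > 100000 nM in this assay, at which 1 of the 3 values shown sits. Within the data shown here, the single measured step, an at least 3.3-fold higher number from compound 1 to compound 2 (0.52 log units; beyond the scatter), is the exchange of bromo in place of trifluoromethyl on an aromatic carbon, and it weakens inhibition by at least a modest amount.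

Compound 4 `Fc1ccc(/C=N/Nc2nc(-c3ccc(F)c(F)c3)cs2)cc1F` differs from compound 2 in one place: 3,4-difluorophenyl in place of 4-bromophenyl on an aromatic carbon. Among the measured compounds shown here, no measured pair covers a 3,4-difluorophenyl, so the step cannot be read from a direct precedent. For the measured compounds named here, the only related evidence is compound 1 with 29900 nM, a fluorinated group on the same ring. Compound 4 is therefore expected to return toward that region, with an estimated 60000 nM, between 25000 nM and 150000 nM, and the expected step from compound 2 being an at least 1.6-fold lower number from compound 2 to compound 4 (0.22 log units; that floor lies within the scatter).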

Compound 4, half-maximal inhibitory concentration: 43900 nM
Compound 4: the middle estimate sits 1.4-fold (0.14 log units) above what was measured, and the stated range covers the measured number.
By their numbers in this assay, from the lowest: compounds 1, 3 and 4 (each within the scatter of the next). At a limit, above all of these: compound 2.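

In this assay, 4-bromophenyl on the aromatic carbon next to the ring nitrogen now has a second replacement, and the exchange for 3,4-difluorophenyl gives an at least 2.2-fold lower number from compound 2 to compound 4 (0.35 log units; beyond the scatter). This shows that the return to a measurable number does not depend on trifluoromethyl: compound 1 gives 29900 nM and compound 4 gives 43900 nM, two values within the usual scatter of each other, so these two groups cannot be told apart in this assay. The true size of the step stays unknown because compound 2 is held only at a limit of the assay: the limit of > 100000 nM in this assay, at which 1 of the 4 values shown sits.

Open, on these data alone, is whether an amine, a carboxylic acid or a plain unsubstituted phenyl at this place would stay in the same range. Also open, as far as these compounds go, is whether 3,4-difluorophenyl behaves alike with the bromo- and methoxy-bearing ring of compound 3.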